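This account rests on a few compounds, and the source may have more. Where it says the series, first, only, none or still open, it means among the compounds named here.

Measured in a functional assay on the whole organism with Rattus norvegicus as the target; on this read-out higher numbers stand for an effect only at larger amounts of compound and lower numbers for an effect already at smaller amounts:
- compound 1 `CCOCCOC(=O)C(=O)Nc1nc(-c2cc(Cl)no2)cs1`: > 30 mg/kg, a limit
- compound 2 `CCOC(=O)C(=O)Nc1nc(-c2cc(Br)no2)cs1`: > 100 mg/kg, a limit
- compound 3 `CC(C)(C)OC(=O)C(=O)Nc1nc(-c2cc(-c3ccccc3)no2)cs1`: 7 mg/kg

Compound 1 stands at the limit of > 30 mg/kg in this assay, at which 1 of the 3 values shown sits, so it has a limit and no number. Of the measured compounds, only compound 3 gives a number in this assay. The next compound is compound 4 `CCOCCOC(=O)C(=O)Nc1nc(-c2cc(C(=O)OCC)no2)cs1`, with ethoxycarbonyl in place of chloro on an aromatic carbon of the core of compound 1: ethoxycarbonyl in place of chloro on an aromatic carbon. For the measured compounds named here, no measured step isolates this change, so the basis for any expectation is thin. The estimated step of a number no higher from compound 1 to compound 4 (the limit leaves the size open) is expected to stay within the scatter, with no direction favoured. Compound 4 is expected at 30 mg/kg, with an estimated range of 10 mg/kg to 100 mg/kg.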

Compound 4, dose for half-maximal effect: 1.9 mg/kg
The estimate for compound 4 lay 16-fold (1.20 log units) above the measured number; the whole stated range lies above it.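

On an aromatic carbon next to the ring nitrogen, ethoxycarbonyl in place of chloro gives in this assay an at least 15-fold lower number from compound 1 to compound 4 (1.19 log units; beyond the scatter). The earlier compounds shown here held no step isolating this position, and this one shows that a change there alone can move the read-out beyond the scatter. Compound 1 carries a limit and no number, so the full size of the step stays open: the limit of > 30 mg/kg in this assay, at which 1 of the 4 values shown sits.

From the compounds shown here alone, whether the whole ethoxycarbonyl is needed stays open. A carboxylic acid or a primary amide in the same place would separate the carbonyl from the ethyl part.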